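Reversing the linker arm: plasma stability of compound 4

This account rests on a few compounds, and the source may have more. Where it says the series, first, only, none or still open, it means among the compounds named here.

Compound 3 `Cc1c(OCCCCOCOc2ccc(C(=O)O)cc2)ccc(C(=O)CC2CCCC2)c1O` gives 100% in an ADME assay on a cell-free system (plasma, Rattus norvegicus) for metabolic stability, read by LC-MS, with a stated time of 60 min, tested at 100 uM (a lower number here means that less of the compound is left, a higher number that more of the compound is left), the second highest of three numbers. Compound 1 `COc1cc(C(=O)O)ccc1OCCCCOc1ccc(C(=O)CC(C)C)c(O)c1C` gives 99%, within the scatter of compound 3, whereas compound 2 `Cc1c(OCCCCOc2ccc(C(=O)O)cc2Cl)ccc(C(=O)CC2CCCC2)c1O` gives 120%, beyond it. Compound 4 `Cc1cc(OCCCCOc2ccc(C(=O)CC3CCCC3)c(O)c2C)ccc1C(=O)O` differs from compound 3 in one place: 4-carboxy-3-methylphenyl in place of (4-carboxyphenoxy)methyl on an oxygen on a saturated carbon. Going by the values given here, the one step that bears on this is a number 20 percentage points lower from compound 2 to compound 3 (beyond the scatter), where 4-carboxy-2-chlorophenyl gave way to (4-carboxyphenoxy)methyl; compound 4 undoes that kind of change. Yet compound 1, which likewise lacks the (4-carboxyphenoxy)methyl, shows no gain over compound 3. The expected step is therefore modest, a number 5 percentage points higher from compound 3 to compound 4 (within the scatter), upward if anything. Compound 4 is estimated to give 105%, within 90% to 125%.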

Compound 4, percent of the compound remaining: 114%
For compound 4 the middle estimate is 9 percentage points below the measured one; low and high end bracket the measured number.
By their numbers in this assay, from the lowest: compounds 1 and 3 (each within the scatter of the next); then compounds 4 and 2 (each within the scatter of the next).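

In this assay, placing 4-carboxy-3-methylphenyl on this oxygen instead of (4-carboxyphenoxy)methyl gives a number 14 percentage points higher from compound 3 to compound 4 (beyond the scatter), so the direct swap at this position moves the number by more than the usual scatter. Exchanging 4-carboxy-2-chlorophenyl for the same group gives a number 6 percentage points lower from compound 2 to compound 4 (within the scatter), so these two carboxyphenyl groups cannot be told apart here. Nothing available explains either step. The compounds shown leave open how a plain 4-carboxyphenyl group would read at this position. They also leave open what an amide in place of the carboxylic acid would do.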